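Aryl swap on the ring nitrogen: compound 2 to compound 4

This account rests on a few compounds, and the source may have more. Where it says the series, first, only, none or still open, it means among the compounds named here.

Of the compounds shown here, three that share one core have been measured in a functional assay on CHO cells with adenosine receptor A1 (Homo sapiens) as the target, read by cAMP accumulation and immunoassay, with a stated time of 6 min, tested at 0.1 uM; on this read-out higher numbers stand for a weaker effect at the one concentration tested and lower numbers for a stronger effect. Compound 1 `CC(C)N1CCN(Cc2csc(N)c2C(=O)c2ccc(Cl)cc2)CC1` gives 3.6%, compound 2 `COc1ccc(N2CCN(Cc3csc(N)c3C(=O)c3ccc(Cl)cc3)CC2)cc1` gives 0%, and compound 3 `Nc1scc(CN2CCN(c3ccc([N+](=O)[O-])cc3)CC2)c1C(=O)c1ccc(Cl)cc1` gives -13%. Compound 2 stands second highest of the three, close to compound 1 and clearly apart from compound 3. The step of a number 3.6 percentage points lower from compound 1 to compound 2 (within the scatter) lies within the scatter, whereas a number 13 percentage points lower from compound 2 to compound 3 (beyond the scatter) and a number 16.6 percentage points lower from compound 1 to compound 3 (beyond the scatter) lie beyond it. Compound 4 `Nc1scc(CN2CCN(c3ccccc3F)CC2)c1C(=O)c1ccc(Cl)cc1` differs from compound 2 by 2-fluorophenyl in place of 4-methoxyphenyl on an amine nitrogen in a ring. Going by the values given here, no measured step exchanges one aryl group for another; only a number 13 percentage points lower from compound 2 to compound 3 (beyond the scatter) shows that a change on the aromatic ring can move the number modestly. The expected step of a number 3 percentage points lower from compound 2 to compound 4 (within the scatter) is therefore small, with no firm direction. Compound 4 is estimated at -3%, in the range -15% to 9%.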

Compound 4, a percentage reported as activity, at one concentration (the size of the read-out at that concentration, not a potency): -1%
The estimate for compound 4 lay 2 percentage points below the measured number; low and high end bracket the measured number.
By their numbers in this assay, from the lowest: compound 3; then compounds 4, 2 and 1 (each within the scatter of the next).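

Swapping 4-methoxyphenyl for 2-fluorophenyl on the ring nitrogen gives a number 1 percentage points lower from compound 2 to compound 4 (within the scatter) in this assay, and replacing isopropyl with 2-fluorophenyl gives a number 4.6 percentage points lower from compound 1 to compound 4 (within the scatter), so neither change separates compound 4 from its neighbours. Aryl on this nitrogen therefore does not alone set the number, since 4-nitrophenyl stays apart, with a number 12 percentage points higher from compound 3 to compound 4 (beyond the scatter) on going to 2-fluorophenyl. No evidence bears on the reason for this. On these data alone, it remains open whether a nitrile or a carboxylic acid on the phenyl ring would group with compound 3. As far as these compounds go, whether unsubstituted phenyl or benzyl on this nitrogen would group with compound 4 is equally open.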